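The source may report more compounds than this note shows. Statements on the series, on what has been measured and on what is new or still open speak of the compounds shown alone.

In an ADME assay on HEK-293T cells (Homo sapiens) for inhibition, read by CCK-8 assay, with a stated time of 48 h, tested at 20 uM (on this read-out lower numbers stand for less inhibition of growth and higher numbers for more inhibition of growth at the one concentration tested), compound 1 `N#C/C(=C\c1ccccc1OS(=O)(=O)c1ccc(Cl)cc1)C(=O)Nc1nnc(Cc2ccccc2)s1` gives 25% and compound 2 `N#C/C(=C\c1ccccc1OS(=O)(=O)c1ccc(Cl)cc1)C(=O)Nc1nnc(Cc2ccc(F)cc2)s1` gives 6%, the lower of the two numbers. The fluoro in place of hydrogen on an aromatic carbon that separates them amounts to a number 19 percentage points lower from compound 1 to compound 2 (beyond the scatter). Compound 3 `N#C/C(=C\c1ccccc1OS(=O)(=O)c1ccc(Cl)cc1)C(=O)Nc1nnc(-c2cccc(F)c2)s1`, not yet measured, keeps the shared core and changes one group: 3-fluorophenyl in place of 4-fluorobenzyl on an aromatic carbon of a five-membered aromatic ring with 2 nitrogen and 1 sulfur. For the measured compounds named here, only that one measured step bears on this change, and only loosely: it swaps hydrogen for fluoro, and no measured pair exchanges a benzyl group for a phenyl group. Compound 3 carries a fluoro as compound 2 does, so a move no larger than that step is expected, and the value of compound 2, 6%, leaves more room upward than downward. The expected change, an upward one, is a number 8 percentage points higher from compound 2 to compound 3 (within the scatter). For compound 3 the estimated value is 14%, with an expected range from 0% to 35%.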

Compound 3, percent growth inhibition at one concentration: 29%
Beside the measured number, compound 3's estimate is 15 percentage points below it, within the range that was stated.
By their numbers in this assay, from the lowest: compound 2; then compounds 1 and 3 (each within the scatter of the next).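

In this assay this position on the shared core turns out to accept a directly attached aryl group as well as a benzyl group: 3-fluorophenyl in place of 4-fluorobenzyl amounts to a number 23 percentage points higher from compound 2 to compound 3 (beyond the scatter) and 3-fluorophenyl in place of benzyl amounts to a number 4 percentage points higher from compound 1 to compound 3 (within the scatter) on this read-out. A fluoro on the outer aromatic ring therefore does not by itself go with the low number of compound 2, for compound 3 also carries one and lies within the scatter of compound 1. Nothing measured here speaks to why the numbers fall this way.

Compound 3 differs from compound 2 both in the lost benzyl carbon and in where the fluoro sits on the ring, and the compounds shown cannot tell which of the two carries the step. From the compounds shown here alone, how a plain phenyl group, a longer chain such as phenethyl, or an amine at this place would read also stays open.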